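Imide Nitrogen: From Methyl to 4-Methoxyphenyl

This account rests on a few compounds, and the source may have more. Where it says the series, first, only, none or still open, it means among the compounds named here.

Compound 1: `CC(C)[C@@H]1CC[C@@H](C)C[C@@]12N(C)C(=O)[C@@H]1[C@H]3C(=O)NC(=O)[C@H]3ON12` gives 42.6% in a functional assay, read by spectrophotometry, with a stated time of 2 h, tested at 1 mg/mL; on this read-out higher numbers stand for a stronger effect at the one concentration tested and lower numbers for a weaker effect.
Compound 2: `CC(C)[C@@H]1CC[C@@H](C)C[C@@]12N(C)C(=O)[C@@H]1[C@H]3C(=O)N(C)C(=O)[C@H]3ON12` gives 41.5% in this assay.

Within this pair, compound 2 has the lower of the two numbers, but the step of a number 1.1 percentage points lower from compound 1 to compound 2 (within the scatter) is within the scatter, so the two compounds cannot be told apart on this read-out; compound 2 simply sits where compound 1 sits.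

Compound 3, `COc1ccc(N2C(=O)[C@H]3[C@H](ON4[C@@H]3C(=O)N(C)[C@@]43C[C@H](C)CC[C@H]3C(C)C)C2=O)cc1`, has not yet been tested. It differs from compound 2 by 4-methoxyphenyl in place of methyl on an amide-type nitrogen in a ring. Within the data shown here, the only measured step, from compound 1 to compound 2, exchanges a hydrogen for a methyl at the same kind of nitrogen and changes nothing beyond the scatter. It gives no direct guidance on a 4-methoxyphenyl, which is a much larger change than any yet measured, so the data offer no footing for predicting a shift in either direction in this assay.

Compound 3 is therefore estimated to give 40%, with a range from 20% to 60%. The step this estimate implies, a number 1.5 percentage points lower from compound 2 to compound 3 (within the scatter), is expected to stay within the scatter, though the range is left wide because compound 2 alone, at 41.5%, is the only anchor.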

Compound 3, a percentage reported as activity, at one concentration (the size of the read-out at that concentration, not a potency): 61%
Compound 3: the middle estimate sits 21 percentage points below what was measured; measured number outside the range, above it.
By their numbers in this assay, from the lowest: compounds 2 and 1 (each within the scatter of the next); then compound 3.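

In this assay, the amide-type nitrogen in a ring proves to be a position where the choice of group can matter: 4-methoxyphenyl in place of methyl gives a number 19.5 percentage points higher from compound 2 to compound 3 (beyond the scatter), and 4-methoxyphenyl in place of the amide hydrogen gives a number 18.4 percentage points higher from compound 1 to compound 3 (beyond the scatter). Hydrogen and methyl alone gave no hint of this, so the flat result between them holds only for that small change and does not describe the position as a whole. The position also accepts a group much larger than methyl, with a six-membered aromatic ring, without any drop in the read-out, though no measurement here bears on why the number rises.

The compounds shown leave open whether the aromatic ring alone accounts for the higher number or whether the methoxy group on it contributes, which a plain phenyl on the same nitrogen would help to separate. They also leave open whether a ring is needed at all, or whether a longer chain such as butyl, or a benzyl group, would give a similar number.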